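This account rests on a few compounds, and the source may have more. Where it says the series, first, only, none or still open, it means among the compounds named here.

Working notes on the series, read in an ADME assay on Raji cells (Homo sapiens) for cytotoxicity, with a stated time of 72 h; on this read-out lower numbers stand for an effect already at smaller amounts and higher numbers for an effect only at larger amounts of compound. Compound 1 (`Cc1cc(NC(=O)Nc2ccccc2OC(F)(F)F)c2ccccc2n1`) gives > 25000 nM, which is a limit of the assay and not a number. Compound 2 (`COc1ccccc1NC(=O)Nc1cc(C)nc2ccccc12`) gives > 25000 nM, again only a limit. Within the data shown here, compound 2 therefore has no exact position, and the series so far amounts to the limit of > 25000 nM in this assay, at which 2 of the 2 values shown sit.

Compound 3 (`Cc1cc(NC(=O)Nc2ccccc2C(F)(F)F)c2ccccc2n1`) is the next to be read. Relative to compound 2 it carries trifluoromethyl in place of methoxy on an aromatic carbon, ortho to a large group.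

Among the measured compounds shown here, only one measured step bears on this, a step that the two limits leave unreadable from compound 1 to compound 2. That step involves methyl in place of trifluoromethyl on an oxygen on an aromatic ring, which is a different exchange, and it offers no size to carry over. No shift in either direction is therefore expected beyond the usual scatter, and another report as a limit in this assay is the likely outcome. The expected change is a step that the limit leaves unreadable from compound 2 to compound 3, with no direction favoured. For compound 3 the estimated value is 30000 nM, within an expected range of 15000 nM to 60000 nM.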

Compound 3, half-maximal effective concentration: > 25000 nM
Compound 3: no number, only a limit; the forecaster's own chance of this, stated with the estimate: 85%; the middle value lies beyond the limit too.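

No step can be read among compound 1, compound 2 and compound 3 in this assay, and the series stays at a single limit of the assay: the limit of > 25000 nM in this assay, at which 3 of the 3 values shown sit.

The compounds shown leave open whether trifluoromethoxy, methoxy and trifluoromethyl differ at all on this read-out, and if so, in which direction and by how much.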